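A few compounds are considered here, and "the series" means these few. Any claim that something is new, unique, unknown or untested is made for them only; others in the source may bear on it.

Working notes on the series. Among the compounds with values here, compound 1 `Cc1cnn(-c2ccc(C)nc2C(=O)N2CC3(CC3)C[C@H]2CNc2ccc(C(F)(F)F)cn2)c1` gives 8.9 in a functional assay on CHO cells for antagonist activity at Orexin/Hypocretin receptor type 1 (Homo sapiens), read by FLIPR and calcium flux (on this read-out higher numbers stand for higher potency (the scale is a negative logarithm) and lower numbers for lower potency), the higher of the two numbers measured so far. Compound 2 `O=C(c1cc(Cl)ccc1-c1ncccn1)N1CC2(CC2)C[C@H]1CNc1cc(C(F)(F)F)ccn1` gives 8.1 in this assay, a number lower than that of compound 1 by a margin beyond the scatter; the two structures differ in several places at once, so no single change accounts for that gap.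

Compound 3 `Cc1ccc(-c2ccccc2)c(C(=O)N2CC3(CC3)C[C@H]2CNc2ccc(C(F)(F)F)cn2)n1` has not been measured. It differs from compound 1 in one place: phenyl in place of 4-methyl-1H-pyrazol-1-yl on an aromatic carbon. The shared core of compound 1 and the rest of the molecule are unchanged. Within the data shown here, with no measured pair that isolates this change, the direction is open; a small loss or no change beyond the scatter is expected, since only compound 2 carries another aryl group there and its lower value reflects several changes. For compound 3, a value of 8.5 in this assay is estimated, within 7.9 to 9.1. The expected step is a number 0.40 log units lower from compound 1 to compound 3 (beyond the scatter).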

Compound 3, negative logarithm of the antagonist equilibrium constant: 8.6
Compound 3: middle estimate off by 0.10 log units, on the low side, within the range that was stated.
By their numbers in this assay, from the lowest: compound 2; then compounds 3 and 1 (each within the scatter of the next).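

In this assay, within the data shown here, phenyl in place of 4-methyl-1H-pyrazol-1-yl gives a number 0.30 log units lower from compound 1 to compound 3 (within the scatter), the first comparison that isolates this aromatic carbon. For this one pair, the position accepts a six-membered aromatic ring of carbon only, with 0 hydrogen-bond acceptors, in place of a five-membered aromatic ring with 2 hetero atoms and 2 hydrogen-bond acceptors, with no step beyond the scatter. No measurement at hand explains this outcome.

Still open, on these data alone, is how an amine, a carboxylic acid or a longer chain on this same carbon would read in this assay. Also open, as far as these compounds go, is whether a phenyl bearing a fluorine or a nitrile would stay within the scatter of compound 1.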